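Replacing bromo with ethynyl: compound 3 to compound 4

The source may hold more compounds than are shown below. What is called first, only, known or untested is meant among the compounds shown, and "the series" means these compounds.

Measured in a functional assay on MDA-MB-231 cells (Homo sapiens) for antiproliferative activity, read by MTT assay, with a stated time of 72 h (on this read-out lower numbers stand for stronger inhibition and higher numbers for weaker inhibition), are these compounds:
compound 1 (`O=C(CCc1cccc2c1B(O)OC2)Nc1nccs1`) gives > 100000 nM as a limit of the assay, not a number
compound 2 (`O=C(CCc1cccc2c1B(O)OC2)Nc1ccc(F)cc1`) gives 440 nM in this read-out
compound 3 (`O=C(CCc1cccc2c1B(O)OC2)Nc1ccc(Br)cc1`) gives 5300 nM in this read-out

Compound 3 carries the higher of the two actual numbers in this assay and compound 2 is its nearest neighbour. The next change leads to compound 4 (`C#Cc1ccc(NC(=O)CCc2cccc3c2B(O)OC3)cc1`), in which ethynyl takes the place of bromo on an aromatic carbon of a six-membered aromatic ring of carbon only, para to a large group (ethynyl in place of bromo on an aromatic carbon). The measured step that bears most directly on this change is the one at that same carbon, a 12-fold higher number from compound 2 to compound 3 (1.08 log units; beyond the scatter) and it was large, so this pair shows that the group there can matter. The steps of an at least 220-fold lower number from compound 1 to compound 2 (2.35 log units; beyond the scatter) and an at least 18-fold lower number from compound 1 to compound 3 (1.27 log units; beyond the scatter) were also large, but they exchange the 1,3-thiazol-2-yl group for a substituted phenyl and say little about this replacement. Going by the values given here, no measured compound carries ethynyl, so the data give no firm direction. A modest step is expected, lower if anything, and the expected change is (a 1.8-fold lower number from compound 3 to compound 4 (0.25 log units; within the scatter)). For compound 4 the estimated value is 3000 nM with an expected range from 500 nM to 15000 nM in this estimate.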

Compound 4, half-maximal inhibitory concentration: 6600 nM
For compound 4 the middle estimate is 2.2-fold (0.34 log units) below the measured one; the range from low to high includes it.
By their numbers in this assay, from the lowest: compound 2; then compounds 3 and 4 (each within the scatter of the next). At a limit, above all of these: compound 1.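

In this assay, ethynyl in place of bromo on this aromatic carbon, para to a large group, brings a change that stays within the scatter, with a 1.2-fold higher number from compound 3 to compound 4 (0.10 log units; within the scatter), so the two groups cannot be told apart in this read-out even though ethynyl brings 2 heavy atoms and a triple bond where bromo has 1 heavy atom. The earlier compounds shown here set fluoro against bromo alone, whereas a 15-fold higher number from compound 2 to compound 4 (1.18 log units; beyond the scatter) now shows a second large step from fluoro at this same carbon, so among the three groups tested here only fluoro stands apart from the others, with compounds 3 and 4 level within the scatter. Nothing measured among these compounds accounts for why bromo and ethynyl read alike or why fluoro differs from both.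

From the compounds shown here alone, it remains open whether the lower number belongs to fluoro alone or would also appear with another group at this carbon, such as chloro, methoxy or an amine. It is also open whether the same order among these groups would hold with a longer chain between the amide carbonyl and the shared core.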